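Swapping Methyl for Chlorophenyl on the Amide Nitrogen

The source may hold more compounds than are shown below. What is called first, only, known or untested is meant among the compounds shown, and "the series" means these compounds.

Among the measured compounds shown here, compound 1 `CCN(Cc1ccccc1)Cc1nc2ccccc2c(-c2ccccc2)c1C(=O)N(C)C` is the one compound here with a measured number: in an assay on brain with Translocator protein (Rattus norvegicus) as the target (on this read-out lower numbers stand for stronger inhibition and higher numbers for weaker inhibition), compound 1 gives 229 nM. Compound 2 `CCN(Cc1ccccc1)Cc1ccccc1C(=O)N(C)c1ccccc1` returns only a limit of the assay rather than a number, since in this assay compound 2 gives > 10000 nM, which is the limit of > 10000 nM in this assay, at which 1 of the 2 values shown sits. Compound 3 `CCN(Cc1ccccc1)Cc1nc2ccccc2c(-c2ccccc2)c1C(=O)N(C)c1ccc(Cl)cc1` has not yet been measured. It differs from compound 1 by 4-chlorophenyl in place of methyl on an amide-type nitrogen. For the measured compounds named here, no measured pair of compounds shows this change on its own, so its effect cannot be read off from the data at hand. In this assay the step from compound 1 to compound 3 is expected to be modest and towards stronger inhibition, estimated as a 3.3-fold lower number from compound 1 to compound 3 (0.51 log units; beyond the scatter). For compound 3 the expected value is 70 nM, with a likely range from 12 nM to 600 nM.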

Compound 3, half-maximal inhibitory concentration: 2480 nM
Estimate against measurement, compound 3: 35-fold (1.55 log units) below; the whole stated range lies below it.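

Read in this assay, this is the first direct look at the amide-type nitrogen, and it shows that the position responds strongly to what it carries: 4-chlorophenyl in place of methyl gives an 11-fold higher number from compound 1 to compound 3 (1.03 log units; beyond the scatter), which means clearly weaker inhibition. Even so, compound 3 gives 2480 nM, a real number and not a limit of the assay, so this change on the core of compound 1 weakens inhibition without pushing it out of measurable range. Nothing shown explains why this change weakens inhibition.

As far as these compounds go, it remains open whether the loss comes from the phenyl ring itself or from its chlorine, and a plain phenyl on this nitrogen would separate the two. An ethyl group in the same place would show whether a small step up from methyl already costs inhibition.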